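From compound 3 to compound 4

A few compounds are considered here, and "the series" means these few. Any claim that something is new, unique, unknown or untested is made for them only; others in the source may bear on it.

Measured so far in a physicochemical assay for permeability, using PAMPA (on this read-out higher numbers stand for higher permeability and lower numbers for lower permeability), are three compounds:
- compound 1 `Cc1ccccc1-c1nc(CN2CCC(C(=O)NCCCN3CC(C)(C)CC(C)(C)C3)CC2)c(C)o1` gives > 1390 10^-6 cm/s as a limit of the assay
- compound 2 `Cc1ccccc1-c1nc(CN2CCC(C(=O)NCCCN3[C@H](C)CCC[C@@H]3C)CC2)c(C)o1` gives 55.4 10^-6 cm/s
- compound 3 `Cc1ccccc1-c1nc(CN2CCC(C(=O)NCCCN3CC4CCCC(C4)C3)CC2)c(C)o1` gives 331 10^-6 cm/s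

Of the two values that are true numbers, compound 3 holds the higher. Compound 4 `Cc1ccccc1-c1nc(CN2CCC(C(=O)NCCN3C[C@H](C)C[C@H](C)C3)CC2)c(C)o1` is now to be measured, and the change leading to it is a group of 8 heavy atoms (7 carbon, 1 nitrogen; one six-membered non-aromatic ring with 1 hetero atom) in place of a group of 10 heavy atoms (9 carbon, 1 nitrogen; one six-membered non-aromatic ring of carbon only, one six-membered non-aromatic ring with 1 hetero atom), on a saturated chain carbon, two bonds along the chain from an amide-type nitrogen with 3,5-dimethylpiperidin-1-yl as the entering group. Within the data shown here, three measured steps bear on it, namely an at least 25-fold lower number from compound 1 to compound 2 (1.39 log units; beyond the scatter) and an at least 4.1-fold lower number from compound 1 to compound 3 (0.62 log units; beyond the scatter) and a 6.0-fold higher number from compound 2 to compound 3 (0.78 log units; beyond the scatter) and all of them lie beyond the scatter. They sit three bonds along the chain, not two, and from compound 3 they run both ways. The expected move is therefore a 1.7-fold lower number from compound 3 to compound 4 (0.22 log units; within the scatter) in this assay and no change beyond the scatter is expected. Compound 4 is estimated at 200 10^-6 cm/s with an expected range from 50 10^-6 cm/s to 800 10^-6 cm/s in this read-out.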

Compound 4, apparent permeability: 712 10^-6 cm/s
Compound 4: middle estimate off by 3.6-fold (0.55 log units), on the low side; low and high end bracket the measured number.
By their numbers in this assay, from the lowest: compound 2; then compound 3; then compound 4. At a limit, above all of these: compound 1.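

In this assay, 3,5-dimethylpiperidin-1-yl two bonds along the chain from an amide-type nitrogen gives a 2.2-fold higher number from compound 3 to compound 4 (0.33 log units; beyond the scatter), a 13-fold higher number from compound 2 to compound 4 (1.11 log units; beyond the scatter) and an at least 1.9-fold lower number from compound 1 to compound 4 (0.29 log units; that floor lies within the scatter). Compound 1 gives a limit: the limit of > 1390 10^-6 cm/s in this assay, at which 1 of the 4 values shown sits. Compound 4 is the first of these compounds with its amine group at two bonds rather than three, yet all three steps also change the amine group, so none isolates the chain.

The compounds shown leave open how 2,6-dimethylpiperidin-1-yl would read at two bonds and 3,5-dimethylpiperidin-1-yl at three. They also leave open how an unsubstituted piperidin-1-yl or a morpholin-4-yl group would read at this place.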